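Quinolinone series: cytotoxicity on bladder carcinoma cells

The compounds below may be only part of what the source reports. "The series", "measured", "known", "first", "only" and "open" are said of these compounds alone.

Measured compounds:
- compound 1 `COc1ccc2cc(-c3ccccc3)c(O)nc2c1`: 10000 nM
- compound 2 `COc1ccc(-c2cc3c(OC)ccc(OC)c3nc2O)cc1`: 10000 nM
- compound 3 `COc1ccc(-c2cc3c(OC)cc(OC)cc3n(C)c2=O)cc1`: 10000 nM

In a functional assay on T-24 cells (Homo sapiens) for cytotoxicity, read by colorimetric assay and MTT assay (on this read-out higher numbers stand for weaker inhibition and lower numbers for stronger inhibition), compound 1 gives 10000 nM. In this assay compound 2 gives 10000 nM, and compound 3 gives 10000 nM. All three compounds therefore sit at the same value at the digits recorded. Compound 3 stands level with compound 1 and with compound 2, within the scatter of repeated measurements, so nothing in these numbers separates the three.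

Compound 4 `COc1ccc(-c2cc3c(OC)cc(OC)cc3n(CCCC#N)c2=O)cc1` is the next compound of the series and has yet to be measured in this assay. Relative to compound 3 the difference is 2-cyanoethyl in place of hydrogen on a saturated chain carbon bound to an aromatic nitrogen. Among the measured compounds shown here, no step between measured compounds that differ in one place is available, so there is no measured step to set the size of this change against.

Given that compound 3 gives 10000 nM and that the three measured compounds show no spread, the expectation is a step of no change at the digits printed from compound 3 to compound 4 (within the scatter), none beyond the scatter, in either direction. Compound 4 is accordingly estimated at 10000 nM, with a range from 4000 nM to 25000 nM.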

Compound 4, half-maximal inhibitory concentration: 10000 nM
Beside the measured number, compound 4's estimate shows no gap at the digits printed, within the range that was stated.
By their numbers in this assay, from the lowest: compounds 1, 2, 3 and 4 (each within the scatter of the next).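

In this assay the series now has its first step read at a single place: no change at the digits printed from compound 3 to compound 4 (within the scatter) for 2-cyanoethyl in place of hydrogen on a saturated chain carbon bound to an aromatic nitrogen. Cut one bond further out, the same difference reads methyl to 3-cyanopropyl, so this place carries a chain ending in a nitrile with no change from the value of compound 3. Nothing measured here offers an explanation for this result.

From the compounds shown here alone, whether a primary amine, a carboxylic acid or a longer chain without the nitrile at this place would give a value apart from that of compound 3 remains open. Changes elsewhere on the shared core cannot be read from single-place steps among the compounds shown.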